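Benzyl in place of fluorophenyl on the triazole nitrogen

This account rests on a few compounds, and the source may have more. Where it says the series, first, only, none or still open, it means among the compounds named here.

Measured so far:
compound 1 `Fc1ccccc1Cn1cc(CSC(=S)N2CCNCC2)nn1` — 19400 nM
compound 2 `CC(C)(C)OC(=O)N1CCN(C(=S)SCc2cn(-c3ccccc3F)nn2)CC1` — 119000 nM

In a functional assay on MGC-803 cells (Homo sapiens) for inhibition, read by MTT assay, with a stated time of 72 h (on this read-out lower numbers stand for stronger inhibition and higher numbers for weaker inhibition), compound 2 gives the highest of the two numbers, with compound 1 as its nearest neighbour at a lower number beyond the scatter. Compound 3 `CC(C)(C)OC(=O)N1CCN(C(=S)SCc2cn(Cc3ccc(Cl)cc3)nn2)CC1` differs from compound 2 by 4-chlorobenzyl in place of 2-fluorophenyl on an aromatic nitrogen. For the measured compounds named here, no pair differing in one place has been measured, so the size of this step is not known from the data. Going by the values given here, compound 1, the only benzyl-bearing member, also carries an unprotected piperazine, so its lower number cannot be tied to the benzyl alone. A step toward a lower number, beyond the scatter, is expected a 2.4-fold lower number from compound 2 to compound 3 (0.38 log units; beyond the scatter). Compound 3 is estimated at 50000 nM, within 15000 nM to 160000 nM.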

Compound 3, half-maximal inhibitory concentration: 9790 nM
For compound 3 the middle estimate is 5.1-fold (0.71 log units) above the measured one; measured number outside the range, below it.
By their numbers in this assay, from the lowest: compounds 3 and 1 (each within the scatter of the next); then compound 2.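

In this assay the first pair differing in one place gives this position a size: 4-chlorobenzyl in place of 2-fluorophenyl on the aromatic nitrogen yields a 12-fold lower number from compound 2 to compound 3 (1.08 log units; beyond the scatter) with the rest of the structure unchanged. The group on this nitrogen can therefore move the number by a large step. No measurement at hand accounts for this step.

The change alters both the link to the aromatic ring and the halogen, and their shares cannot be separated. Plain benzyl or 4-chlorophenyl on the core of compound 3 would separate them.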